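Methoxy for Cyano: an Early Guess at EED Binding

A few compounds are considered here, and "the series" means these few. Any claim that something is new, unique, unknown or untested is made for them only; others in the source may bear on it.

Compound 2 `Cc1ncccc1-c1cnc(NCc2c(F)cc(C#N)c3c2CCO3)n2cnnc12` was tested in an assay on isolated protein for binding affinity to Polycomb protein EED (Homo sapiens), read by surface plasmon resonance (a higher number here means weaker binding, a lower number tighter binding), and gives 15000 nM, a weak interaction. Going by the values given here, compound 1 `Cc1ncccc1-c1cnc(NCc2c(F)cc(C3CC3)c3c2CCO3)n2cnnc12` shares the same core but carries a different group where compound 2 has its cyano; in this assay compound 1 has "not determined" (no result reported), so compound 2 holds the only number in this set and there is nothing to compare it against.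

Compound 3 `COc1cc(F)c(CNc2ncc(-c3cccnc3C)c3nncn23)c2c1OCC2` is the next compound to be measured. It differs from compound 2 in one place: methoxy in place of cyano on an aromatic carbon. Both groups are small and both count one hydrogen-bond acceptor, so the change is modest in size. Among the compounds with values here, no measured pair shows what such a swap does here, and the only anchor is the weak binding of compound 2.

The expected step is a 1.3-fold lower number from compound 2 to compound 3 (0.10 log units; within the scatter), small and with no clear direction beyond the scatter. Compound 3 is therefore estimated at 12000 nM, within a range from 3000 nM to 50000 nM, and a limit rather than a number remains possible in this assay.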

Compound 3, dissociation constant: 305000 nM
Estimate against measurement, compound 3: 25-fold (1.41 log units) below, outside the stated range (above it).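

In this assay, placing methoxy where cyano stood gives a 20-fold higher number from compound 2 to compound 3 (1.31 log units; beyond the scatter), so this aromatic carbon is sensitive to the group it carries, and compound 2, weak as it is, binds more tightly than compound 3. The two groups have the same heavy-atom count and the same hydrogen-bond acceptor count, and neither has a hydrogen-bond donor or a net charge, so matching these counts did not keep the binding unchanged. Nothing available here explains the difference between these two groups.

This single pair cannot show whether the loss follows from adding methoxy or from removing cyano, nor whether any group at this carbon would bind much more tightly than compound 2 does. A plain methyl group, a chlorine atom or a bare hydrogen on the same carbon would give further points for comparison, while compound 1, with "not determined" (no result reported), offers no number to set beside these two.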